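Aryl amide variation on the shared core: methoxyphenyl replacement

The source may report more compounds than this note shows. Statements on the series, on what has been measured and on what is new or still open speak of the compounds shown alone.

Compound 2 `CCN1CCN(c2cc(C)c3cc(NC(=O)c4ccccc4Br)ccc3n2)CC1` gives 39200 nM in a functional assay on SK-BR-3 cells (Homo sapiens) for antiproliferative activity, read by MTT assay, with a stated time of 72 h (on this read-out higher numbers stand for weaker inhibition and lower numbers for stronger inhibition), the highest number of the three measured compounds. Its nearest neighbour is compound 1 `CCN1CCN(c2cc(C)c3cc(NC(=O)c4ccc(F)cc4)ccc3n2)CC1`, which in this assay gives 19800 nM; the step of a 2.0-fold higher number from compound 1 to compound 2 (0.30 log units; within the scatter) lies within the scatter. Within the data shown here, compound 3 `CCN(CC)CCNc1cc(C)c2cc(NC(=O)c3ccc(Cl)c(Cl)c3)ccc2n1` carries a different amine side chain on the shared core as well as a 3,4-dichlorophenyl amide and gives 3710 nM in this assay; with two differences at once, no single step connects it to compound 2.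

Compound 4 `CCN1CCN(c2cc(C)c3cc(NC(=O)c4ccc(OC)cc4)ccc3n2)CC1` differs from compound 2 in the amide aryl group: 4-methoxyphenyl in place of 2-bromophenyl on a carbonyl carbon. Among the measured compounds shown here, the only measured step bearing on this change is the aryl exchange a 2.0-fold higher number from compound 1 to compound 2 (0.30 log units; within the scatter), which stayed within the scatter; no methoxy-bearing compound has been measured. The step of a 1.6-fold lower number from compound 2 to compound 4 (0.20 log units; within the scatter) is therefore expected to stay small, tending if anything toward the number of compound 1. Compound 4 is estimated at 25000 nM, with a range from 8000 nM to 80000 nM.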

Compound 4, half-maximal inhibitory concentration: 9000 nM
Compound 4: middle estimate off by 2.8-fold (0.44 log units), on the high side; the measured number falls inside the stated range.
By their numbers in this assay, from the lowest: compound 3; then compound 4; then compounds 1 and 2 (each within the scatter of the next).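

Notes on the amide aryl group: this position can move the number beyond the scatter in this assay, which the exchange between compound 1 and compound 2 alone did not show. The 4-methoxyphenyl amide gives a 4.4-fold lower number from compound 2 to compound 4 (0.64 log units; beyond the scatter) and also a 2.2-fold lower number from compound 1 to compound 4 (0.34 log units; beyond the scatter), so methoxy in place of fluoro on an aromatic carbon separates two compounds that share the same ring position, with the direction favouring the methoxy compound in both steps. Nothing measured here explains why this change lowers the number.

Open, going by these compounds, is whether an ethoxy group, an amine or a carboxylic acid in place of methoxy on the aromatic carbon would lower the number further. Also open, on these data alone, is whether 4-methoxyphenyl gives a similar step on the diethylaminoethyl amine side chain of compound 3.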